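From acetyl to cyclopropylcarbonyl on a shared core

A few compounds are considered here, and "the series" means these few. Any claim that something is new, unique, unknown or untested is made for them only; others in the source may bear on it.

In a functional assay on K562 cells (Homo sapiens) for inhibition, read by MTT assay, with a stated time of 48 h (a lower number here means a stronger inhibitor, a higher number a weaker inhibitor), compound 1 `Nc1n[nH]c2cc(-c3cn([C@@H]4CN[C@H](C(=O)Nc5ccc(Br)cc5)C4)nn3)ccc12` gives 10300 nM. Among the measured compounds shown here, compound 2 `CC(=O)Nc1n[nH]c2cc(-c3cn([C@@H]4CN[C@H](C(=O)Nc5ccc(Br)cc5)C4)nn3)ccc12` carries an acetyl in place of hydrogen on a nitrogen on an aromatic ring and gives 3830 nM, the lower of the two numbers measured so far and so the stronger result.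

Compound 3 `O=C(Nc1n[nH]c2cc(-c3cn([C@@H]4CN[C@H](C(=O)Nc5ccc(Br)cc5)C4)nn3)ccc12)C1CC1` differs from compound 2 in one place, with cyclopropyl in place of methyl on a carbonyl carbon. The acetyl thus becomes a cyclopropylcarbonyl, while the rest of the molecule stays the same.

For the measured compounds named here, no measured step shows this exact exchange. The closest guide is a 2.7-fold lower number from compound 1 to compound 2 (0.43 log units; beyond the scatter), which is modest but beyond the scatter. That step adds the acetyl rather than altering it, so it gives only a rough sense of scale and no firm direction for the new change. A small change is therefore expected, and the estimate is a 1.2-fold lower number from compound 2 to compound 3 (0.08 log units; within the scatter), which would not stand clear of the scatter. In this assay, the estimated value for compound 3 is 3200 nM, with an expected range from 1300 nM to 7500 nM.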

Compound 3, half-maximal inhibitory concentration: 8080 nM
For compound 3 the middle estimate is 2.5-fold (0.40 log units) below the measured one; measured number outside the range, above it.
By their numbers in this assay, from the lowest: compound 2; then compounds 3 and 1 (each within the scatter of the next).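

In this assay, replacing the methyl on the carbonyl carbon with cyclopropyl gives a 2.1-fold higher number from compound 2 to compound 3 (0.32 log units; beyond the scatter), so what is attached to this carbonyl matters, and not only whether a carbonyl is present. Compared with the compound that keeps a hydrogen on this nitrogen, the cyclopropylcarbonyl group gives a 1.3-fold lower number from compound 1 to compound 3 (0.11 log units; within the scatter), so the modest gain seen with acetyl does not carry over to this second group, and the nitrogen does not respond to every group of this kind in the same way. No measurement shown here explains why these two closely related groups differ in this cell assay.

With only methyl and cyclopropyl on this carbonyl, the compounds shown cannot tell whether acetyl is a narrow optimum or simply one point in a wider, still unmapped series. Ethyl, isopropyl or a longer chain in this place would help to settle that, and a carbonyl carrying a phenyl ring or an amine would show whether anything other than a small carbon group can do better than compound 2.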